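A few compounds are considered here, and "the series" means these few. Any claim that something is new, unique, unknown or untested is made for them only; others in the source may bear on it.

Measured so far:
Compound 1 `O=C(O)CC1CCN(Cc2cc(Oc3cnc(N4CCNCC4)nc3)nc(-c3cc(Cl)cc(Cl)c3)c2)CC1`: -11%
Compound 2 `CN1CCN(c2cnc(Oc3cc(CN4CCC(CC(=O)O)CC4)cc(-c4cc(Cl)cc(Cl)c4)n3)cn2)CC1`: 22%

In a functional assay on the whole organism for inhibition, with Mus musculus as the target, at a dose of 10 mg/kg by the oral route (on this read-out lower numbers stand for less inhibition and higher numbers for more inhibition at the one dose given (going by the name of the read-out)), compound 1 gives -11%, the lowest of the two numbers. Compound 2 gives 22%, a number higher by more than the usual scatter. Within the data shown here, no single-point step joins these two compounds, so only their two values can be set side by side. Compound 3 `CS(=O)(=O)CCCN1CCN(c2ncc(Oc3cc(CN4CCC(CC(=O)O)CC4)cc(-c4cc(Cl)cc(Cl)c4)n3)cn2)CC1` has not yet been measured. It differs from compound 1 in one place: 3-(methylsulfonyl)propyl in place of hydrogen on an amine nitrogen in a ring. The new group sits on an amine nitrogen in a ring of a six-membered non-aromatic ring, the nitrogen that carries a hydrogen in compound 1. Among the measured compounds shown here, the values of compound 1 and compound 2 are the only guide. On that basis the expected step is a number 23 percentage points higher from compound 1 to compound 3 (beyond the scatter), upward and roughly at the edge of the scatter. For compound 3 the expected value in this assay is 12%, within a range from -12% to 38%.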

Compound 3, a percentage reported as inhibition, in the whole organism at one dose (the size of the read-out at that dose, not a potency): 40%
For compound 3 the middle estimate is 28 percentage points below the measured one, and the stated range ends below it.
By their numbers in this assay, from the lowest: compound 1; then compound 2; then compound 3.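

In this assay, 3-(methylsulfonyl)propyl in place of hydrogen on an amine nitrogen in a ring gives a number 51 percentage points higher from compound 1 to compound 3 (beyond the scatter). Among these compounds, this is the first comparison that isolates a change at this nitrogen, and it shows that the hydrogen of compound 1 can be replaced by a chain of this size with a gain rather than a loss in this assay. No measurement shown here accounts for the size of this step.

The compounds shown leave open whether the gain requires the methylsulfonyl group or comes with the propyl chain alone, a question that a plain propyl group on the same nitrogen would address. They also leave open how a shorter chain such as 2-(methylsulfonyl)ethyl, or a carboxylic acid in place of the methylsulfonyl group, would read at this nitrogen.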